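The source may hold more compounds than are shown below. What is called first, only, known or untested is meant among the compounds shown, and "the series" means these compounds.

Working notes on the series sharing the core of compound 1. In an ADME assay on HepG2 2.2.15 cells (Homo sapiens) for cytotoxicity, read by CCK-8 assay, with a stated time of 8 days (on this read-out lower numbers stand for higher toxicity in this test and higher numbers for lower toxicity in this test), compound 1 (`CCOc1ccc(-c2cc(NC(=O)c3ccc(OC)cc3O)c[nH]c2=O)cc1`) gives 69600 nM and compound 2 (`CCOc1ccc(-c2cc(NC(=O)c3ccc(F)cc3O)c[nH]c2=O)cc1`) gives 51500 nM so the two values stand within the scatter of each other, and compound 2 holds no separate place on these numbers.

Compound 3 (`CCOc1ccc(-c2cc(NC(=O)c3ccc(C(F)(F)F)cc3O)c[nH]c2=O)cc1`) has not yet been measured. It carries trifluoromethyl in place of fluoro on an aromatic carbon and the site is meta to a hydroxy group and para to a large group.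

Among the measured compounds shown here, one measured step bears on this change, a 1.4-fold lower number from compound 1 to compound 2 (0.13 log units; within the scatter) which is fluoro in place of methoxy on an aromatic carbon. For the measured compounds named here, that exchange did not move the number beyond the scatter, but it is a single step and the series holds no measured trifluoromethyl compound. No step beyond the scatter is therefore expected in this assay and no direction can be assigned with confidence. The estimated change is a 1.1-fold lower number from compound 2 to compound 3 (0.06 log units; within the scatter) as a working expectation.

Compound 3 is estimated at 45000 nM with an expected range from 20000 nM to 95000 nM in this read-out.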

Compound 3, half-maximal cytotoxic concentration: 22200 nM
For compound 3 the middle estimate is 2.0-fold (0.31 log units) above the measured one, within the range that was stated.
By their numbers in this assay, from the lowest: compound 3; then compounds 2 and 1 (each within the scatter of the next).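

Among the compounds shown here, at this position, meta to a hydroxy group and para to a large group, this assay now shows a response to the substituent: trifluoromethyl in place of fluoro gives a 2.3-fold lower number from compound 2 to compound 3 (0.37 log units; beyond the scatter) and is the first exchange to pass the scatter, whereas the earlier exchange of methoxy for fluoro stayed within it. Trifluoromethyl in place of methoxy gives a 3.1-fold lower number from compound 1 to compound 3 (0.50 log units; beyond the scatter) and confirms the same picture from the other side, so compound 3 stands lowest of the three, with its steps to both others printed as beyond the scatter, while compounds 1 and 2 remain within the scatter of each other. The steps are modest, and nothing at hand accounts for the lower number with trifluoromethyl.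

Three compounds cannot show whether the number at this site keeps falling or levels off with other groups, such as a nitrile, a chlorine atom, an amine or a carboxylic acid. On these data alone, whether trifluoromethyl has the same effect at other places on the shared core also remains open.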